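A few compounds are considered here, and "the series" means these few. Any claim that something is new, unique, unknown or untested is made for them only; others in the source may bear on it.

Measured in a physicochemical assay for permeability, using PAMPA; on this read-out lower numbers stand for lower permeability and higher numbers for higher permeability:
- Compound 1 `Cc1ccccc1-c1nc(CN2CCC(C(=O)NCCCN3CCC(C)(C)CC3)CC2)c(C)o1`: 241 10^-6 cm/s
- Compound 2 `Cc1oc(-c2c(Cl)cccc2Cl)nc1CN1CCC(C(=O)NCCCN2C[C@H](C)C[C@H](C)C2)CC1`: "not determined" (no result reported)
- Compound 3 `Cc1oc(-c2c(Br)cccc2Br)nc1CN1CCC(C(=O)NCCCN2C[C@H](C)C[C@H](C)C2)CC1`: < 1 10^-6 cm/s, a limit of the assay and not a number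

Within the data shown here, compound 1, at 241 10^-6 cm/s, holds the only actual number in the set, so it has no measured neighbour to be ranked against. Compound 4 `Cc1ccccc1-c1nc(CN2CCC(C(=O)NCCN3C[C@H](C)C[C@H](C)C3)CC2)c(C)o1` differs from compound 1 by one change: 3,5-dimethylpiperidin-1-yl in place of (4,4-dimethylpiperidin-1-yl)methyl on a saturated chain carbon, two bonds along the chain from an amide-type nitrogen. Among the measured compounds shown here, no measured step covers this change. Compound 3 also carries 3,5-dimethylpiperidin-1-yl, and its < 1 10^-6 cm/s is only a limit. A small downward step in this assay, within the usual scatter, is expected: a 1.9-fold lower number from compound 1 to compound 4 (0.27 log units; within the scatter). For compound 4 the estimated value is 130 10^-6 cm/s, with an expected range of 25 10^-6 cm/s to 350 10^-6 cm/s.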

Compound 4, apparent permeability: 712 10^-6 cm/s
Compound 4: middle estimate off by 5.5-fold (0.74 log units), on the low side; measured number above the stated range.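

In this assay, among these compounds, 3,5-dimethylpiperidin-1-yl in place of (4,4-dimethylpiperidin-1-yl)methyl gives the first measured step: a 3.0-fold higher number from compound 1 to compound 4 (0.47 log units; beyond the scatter). Compound 3 also carries 3,5-dimethylpiperidin-1-yl, but its < 1 10^-6 cm/s is a limit of the assay and not a number. Nothing shown gives a cause for the step.

The step from 3-(4,4-dimethylpiperidin-1-yl)propyl to 2-(3,5-dimethylpiperidin-1-yl)ethyl changes both chain and ring substitution, and the compounds shown do not separate the two. From the compounds shown here alone, how a morpholine or an unsubstituted piperidine would read at this place also remains open.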